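The source may report more compounds than this note shows. Statements on the series, on what has been measured and on what is new or still open speak of the compounds shown alone.

Series notes, measured in a functional assay on HCT-116 cells (Homo sapiens) for antiproliferative activity, with a stated time of 48 h; on this read-out lower numbers stand for stronger inhibition and higher numbers for weaker inhibition:
- compound 1 `CCN(CC)c1ccc(-c2ccc(C(=O)OC)cc2)nn1`: 60 nM
- compound 2 `CCOC(=O)c1ccc(-c2ccc(N(CC)CC)nn2)cc1`: 500 nM
- compound 3 `CCOC(=O)c1ccc(-c2ccc(N(C)C)nn2)cc1`: > 25000 nM (a limit, not a number)

On these data alone, compound 3 stands at > 25000 nM, which is a limit of the assay, so its true position is unknown. Compound 4 `COC(=O)c1ccc(-c2ccc(N(C)C)nn2)cc1` differs from compound 3 by hydrogen in place of methyl on a saturated chain carbon bound to an oxygen next to a carbonyl group, that is, ethoxycarbonyl to methoxycarbonyl.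

Among the compounds with values here, the closest precedent is an 8.3-fold higher number from compound 1 to compound 2 (0.92 log units; beyond the scatter). That is the same change in the opposite sense, seen in the diethylamino pair, so a modest move to a lower number is expected here. It is a single pair, and it may not carry over to the dimethylamino compounds. The other measured step, an at least 50-fold higher number from compound 2 to compound 3 (1.69 log units; beyond the scatter), is large and keeps the expectation high on the scale: even with the methoxycarbonyl group, compound 4 should remain far weaker than compound 1 at 60 nM.

The estimated change is an at least 2.5-fold lower number from compound 3 to compound 4 (0.39 log units; beyond the scatter), and it is counted from a limit. A result reported only as a limit remains quite possible. For compound 4 the expected value is 10000 nM, with an estimated range of 3000 nM to 40000 nM.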

Compound 4, half-maximal inhibitory concentration: > 25000 nM
Compound 4 gave a limit, no number; the forecaster's own chance of this, stated with the estimate: 35%; middle value at least 2.5-fold (0.39 log units) from the limit.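

In this assay, the change of dimethylamino in place of diethylamino now has a reading with methoxycarbonyl as well as with ethoxycarbonyl, an at least 410-fold higher number from compound 1 to compound 4 (2.61 log units; beyond the scatter), so the large move to a higher number is not confined to the ethoxycarbonyl pair. Both pairs point the same way: the same change on two cores in this assay, an at least 50-fold higher number (1.69 log units; beyond the scatter) from compound 2 to compound 3 and an at least 410-fold higher number (2.61 log units; beyond the scatter) from compound 1 to compound 4; the limit leaves it open whether they differ. The change of ethoxycarbonyl to methoxycarbonyl, with its clear step in the diethylamino pair, cannot be read in the dimethylamino pair, as both compounds there sit at a limit of the assay: the limit of > 25000 nM in this assay, at which 2 of the 4 values shown sit.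

On these data alone, with both dimethylamino compounds at that limit, it remains open how far their true values lie from it and whether the ester change has any effect in that pair. Also open, as far as these compounds go, is how the read-out responds to a longer chain on the amine, such as dipropylamino, or to a carboxylic acid in place of the methoxycarbonyl group on the core of compound 1.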